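Aryl halogen swap on the fused bicyclic ketone series

This account rests on a few compounds, and the source may have more. Where it says the series, first, only, none or still open, it means among the compounds named here.

Measured compounds:
compound 1 `CC(C)C1CC(=O)c2s/c(=N/c3ccccc3)oc2C1`, 2190 nM
compound 2 `CC1(C)CC(=O)c2s/c(=N/c3ccc(Cl)cc3)oc2C1`, 4260 nM
compound 3 `CC1CC(=O)c2s/c(=N/c3ccc(Cl)cc3)oc2C1`, 16500 nM

In a functional assay on PC-3 cells (Homo sapiens) for antiproliferative activity, read by sulforhodamine B assay (on this read-out lower numbers stand for stronger inhibition of growth and higher numbers for weaker inhibition of growth), compound 2 gives 4260 nM, the second highest of the three numbers. Compound 1 gives 2190 nM, which lies within the scatter of the value of compound 2, so the two cannot be ordered. Within the data shown here, compound 3 gives 16500 nM; the one single-place step recorded, a 3.9-fold higher number from compound 2 to compound 3 (0.59 log units; beyond the scatter), is a change on a saturated ring carbon of the shared core.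

Compound 4 `CC1(C)CC(=O)c2s/c(=N/c3ccc(F)cc3)oc2C1` differs from compound 2 only at the aromatic ring: fluoro in place of chloro on an aromatic carbon, on an aromatic carbon of a six-membered aromatic ring of carbon only, para to a large group. Among the measured compounds shown here, no measured step touches this position; the only step available concerns the saturated ring and does not bear on the halogen exchange. With nothing to push the number either way, a step within the scatter is the expectation, a 1.0-fold higher number from compound 2 to compound 4 (0.00 log units; within the scatter). Compound 4 is therefore estimated at 4300 nM in this assay, with a range from 1500 nM to 12000 nM that reflects the absence of any directly relevant precedent.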

Compound 4, concentration for 50% growth inhibition: 2450 nM
Compound 4: the middle estimate sits 1.8-fold (0.24 log units) above what was measured; the range from low to high includes it.
By their numbers in this assay, from the lowest: compounds 1, 4 and 2 (each within the scatter of the next); then compound 3.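

In this assay fluoro in place of chloro on an aromatic carbon, para to a large group, gives a 1.7-fold lower number from compound 2 to compound 4 (0.24 log units; within the scatter) and so does not separate the two halogens on this read-out. Among these compounds, this is the first reading at the aromatic ring with the rest of compound 2 held fixed, and at this position the two halogens cannot be told apart, whereas the earlier single-place step on a saturated ring carbon lay beyond the scatter. Nothing at hand gives a reason for this outcome.

Open, as far as these compounds go, is whether this position responds to anything other than a halogen: a methoxy group, a nitrile or an amine there would test that. Also open, from the compounds shown here alone, is whether the halogen exchange reads the same on the core of compound 3, which carries a single methyl on the saturated ring.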